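The compounds below may be only part of what the source reports. "The series", "measured", "known", "first", "only" and "open" are said of these compounds alone.

In a functional assay on HEL cells (Homo sapiens) for cytotoxicity (a lower number here means that less compound is tolerated, a higher number that more compound is tolerated), compound 1, whose structure is `CCCCCCCCCCc1cc2cn([C@H]3C[C@H](O)[C@@H](CO)O3)c(=O)nc2o1`, gives only a limit, > 50000 nM, so its position on the numbers shown is known only as a floor and not as a measured value; this is the limit of > 50000 nM in this assay, at which 1 of the 3 values shown sits. Two further compounds with a different core share the long chain and were measured fully. Compound 2, with the structure `O=c1[nH]c(=O)n([C@H]2C[C@H](O)[C@@H](CO)O2)cc1C#CCCCCCCCCCF`, gives 116000 nM in this assay. Compound 3, with the structure `O=c1[nH]c(=O)n([C@H]2C[C@H](O)[C@@H](CO)O2)cc1C#CCCCCCCCCCBr`, gives 97000 nM. The step between them, a 1.2-fold lower number from compound 2 to compound 3 (0.08 log units; within the scatter), shows that swapping fluoro for bromo at the chain end left the read-out unchanged within the scatter.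

Compound 4, with the structure `O=c1nc2oc(CCCCCCCCCBr)cc2cn1[C@H]1C[C@H](O)[C@@H](CO)O1`, is the unmeasured partner of compound 1. It differs by bromo in place of methyl on a saturated chain carbon, nine bonds along the chain from an aromatic carbon. Within the data shown here, the one measured step that bears on it is the halogen swap at the chain end between compound 2 and compound 3, which was within the scatter; no measured step exchanges methyl for bromo on the shared core of compound 1. With compound 1 known only as a limit, the expectation is that compound 4 also sits near that floor, with no clear step in either direction.

Compound 4 is therefore estimated at 80000 nM, between 40000 nM and 160000 nM, which would mean an expected step that the limit leaves unreadable from compound 1 to compound 4.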

Compound 4, half-maximal cytotoxic concentration: > 50000 nM
Compound 4 ended at the assay's limit; the forecaster's own chance of this, stated with the estimate: 45%; the middle value is on the limit's open side.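

In this assay, among these compounds, compound 1 and compound 4 both end at a limit of the assay and not at a number, so no step between them can be read: the limit of > 50000 nM in this assay, at which 2 of the 4 values shown sit. The compounds shown leave open whether bromo in place of methyl on this saturated chain carbon changes the half-maximal cytotoxic concentration on the shared core at all.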